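The compounds below may be only part of what the source reports. "The series", "measured", "known", "first", "only" and "open" are said of these compounds alone.

Three compounds of the shared core have numbers in a functional assay on U2OS cells (Homo sapiens) for antiproliferative activity, read by MTT assay, with a stated time of 72 h; a higher number here means a weaker inhibitor, a lower number a stronger inhibitor. Compound 1 `CCOC1=C(C(=O)c2ccccc2)C(c2ccc(Br)cc2)N(CCCn2ccnc2)C1=O` gives 21900 nM, compound 2 `CCCCOC1=C(C(=O)c2ccccc2)C(c2ccc(Br)cc2)N(CCCn2ccnc2)C1=O` gives 32400 nM and compound 3 `CCOc1ccc(NC2=C(C(=O)c3ccccc3)C(c3ccc(Br)cc3)N(CCCn3ccnc3)C2=O)cc1` gives 26200 nM. Compound 2 carries the highest of the three numbers, yet a 1.5-fold higher number from compound 1 to compound 2 (0.17 log units; within the scatter) and a 1.2-fold lower number from compound 2 to compound 3 (0.09 log units; within the scatter) both stay within the scatter, so the three cannot be ranked. Compound 4 `O=C(C1=C(Nc2ccc(I)cc2)C(=O)N(CCCn2ccnc2)C1c1ccc(Br)cc1)c1ccccc1` differs from compound 2 by (4-iodophenyl)amino in place of butoxy on a double-bonded ring carbon. Going by the values given here, the nearest precedent is the exchange of an alkoxy group for an arylamino group, where a 1.2-fold lower number from compound 2 to compound 3 (0.09 log units; within the scatter) and a 1.2-fold higher number from compound 1 to compound 3 (0.08 log units; within the scatter) stayed within the scatter. No step beyond the scatter in this assay is therefore expected from compound 2 to compound 4. Compound 4 is estimated at 28000 nM, within 12000 nM to 65000 nM. The expected step is a 1.2-fold lower number from compound 2 to compound 4 (0.06 log units; within the scatter).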

Compound 4, half-maximal inhibitory concentration: 12000 nM
Compound 4: the middle estimate sits 2.3-fold (0.37 log units) above what was measured; low and high end bracket the measured number.
By their numbers in this assay, from the lowest: compounds 4, 1, 3 and 2 (each within the scatter of the next, the first and the last beyond it).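

Going by these compounds alone, at this double-bonded ring carbon, an arylamino group now separates from butoxy in this assay, with a 2.7-fold lower number from compound 2 to compound 4 (0.43 log units; beyond the scatter) as the first step beyond the scatter at this position. The aromatic substituent also counts, since iodo in place of ethoxy gives a 2.2-fold lower number from compound 3 to compound 4 (0.34 log units; beyond the scatter) on an otherwise unchanged (phenyl)amino group, yet the exchange from ethoxy does not clear the scatter, with a 1.8-fold lower number from compound 1 to compound 4 (0.26 log units; within the scatter) as the exception. No measured evidence here explains these steps. From the compounds shown here alone, whether a bromo, chloro or methyl group at the same place on the phenyl ring follows iodo remains open, as does the unsubstituted phenylamino group.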